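Varying the acyl group on the ring amide

This account rests on a few compounds, and the source may have more. Where it says the series, first, only, none or still open, it means among the compounds named here.

Measured so far:
compound 1, `Cc1nn(-c2ncnc3nc[nH]c23)c2c1C(NC(=O)Cc1cccs1)CC(=O)N2`, 244 nM in a functional assay on HEK293 cells for agonist activity at G-protein coupled receptor 39 (Homo sapiens), read by scintillation proximity assay and inositol phosphate accumulation, with a stated time of 75 min; on this read-out higher numbers stand for an effect only at larger amounts of compound and lower numbers for an effect already at smaller amounts
compound 2, `Cc1nn(-c2ncnc3nc[nH]c23)c2c1C(C(=O)N(C)c1nccs1)CC(=O)N2`, 3300 nM
compound 3, `Cc1nn(-c2ncnc3nc[nH]c23)c2c1C(OCCc1ccccc1)CC(=O)N2`, 40 nM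

Compound 1 stands second highest of the three; a 6.1-fold lower number from compound 1 to compound 3 (0.79 log units; beyond the scatter), and a 14-fold higher number from compound 1 to compound 2 (1.13 log units; beyond the scatter).

Compound 4, `CCC(C(=O)NC1CC(=O)Nc2c1c(C)nn2-c1ncnc2nc[nH]c12)c1ccccc1`, differs from compound 1 by 1-phenylpropyl in place of (thiophen-2-yl)methyl on a carbonyl carbon. Both measured steps from compound 1 exchange the whole acylamino group, once for a carbamoyl and once for an ether, so neither bears directly on swapping only the acyl part while the amide link stays. Going by the values given here, compound 3, the phenethyloxy compound, gives the lowest number, but no step separates that from the change of link, so for compound 4 nothing beyond the scatter is expected. The estimate for compound 4 in this assay is 150 nM (range 40 nM to 600 nM), an expected step of a 1.6-fold lower number from compound 1 to compound 4 (0.21 log units; within the scatter).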

Compound 4, half-maximal effective concentration: 79 nM
For compound 4 the middle estimate is 1.9-fold (0.28 log units) above the measured one, within the range that was stated.
By their numbers in this assay, from the lowest: compounds 3 and 4 (each within the scatter of the next); then compound 1; then compound 2.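

Going by these compounds alone, with the amide link kept, the acyl part alone moves the number in this assay: 1-phenylpropyl in place of (thiophen-2-yl)methyl on a carbonyl carbon gives a 3.1-fold lower number from compound 1 to compound 4 (0.49 log units; beyond the scatter) and is the first step here to leave that link intact. The position therefore accepts a swap of a five-membered aromatic ring with 1 hetero atom for a six-membered aromatic ring of carbon only, together with added chain carbons. No measurement available here accounts for this step.

The ring swap and the added chain remain unseparated, and a plain benzyl group would divide them. From the compounds shown here alone, how a carboxylic acid on the phenyl ring would read also stays open.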